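This account rests on a few compounds, and the source may have more. Where it says the series, first, only, none or still open, it means among the compounds named here.

Compound 1 `O=C(O)Cn1nc(Cc2nc3cc(Cl)c(OCC(F)F)cc3[nH]2)c2ccccc2c1=O`: 33 L/kg
Compound 2 `O=C(O)Cn1nc(Cc2nc3cc(F)c(OCC4CC4)cc3[nH]2)c2ccccc2c1=O`: 28 L/kg

Both numbers come from an ADME assay on the whole organism (Mus musculus, strain CD1) for pharmacokinetics, read by LC-MS, with a stated time of 24 h, at a dose of 1 mg/kg by the intravenous route; on this read-out higher numbers stand for wider distribution into tissues and lower numbers for narrower distribution. Compound 2, at 28 L/kg, stands within the usual scatter of compound 1, at 33 L/kg, so the two values cannot be told apart.

Compound 3 `O=C(O)Cn1nc(Cc2nc3cc(Cl)c(OCC4CC4)cc3[nH]2)c2ccccc2c1=O` keeps the cyclopropylmethoxy group of compound 2 and carries chloro in place of fluoro on an aromatic carbon. This carbon is ortho to the cyclopropylmethoxy group. Going by the values given here, no two measured compounds differ in just one place, so the data give no direct measure of what this swap does. With so little to go on, no step beyond the scatter is expected in this assay, in either direction. The expected change is a 1.1-fold higher number from compound 2 to compound 3 (0.03 log units; within the scatter). Compound 3 is expected at 30 L/kg, with an estimated range of 15 L/kg to 60 L/kg.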

Compound 3, volume of distribution at steady state: 83 L/kg
Estimate against measurement, compound 3: 2.8-fold (0.44 log units) below; the whole stated range lies below it.
By their numbers in this assay, from the lowest: compounds 2 and 1 (each within the scatter of the next); then compound 3.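

In this assay the swap of fluoro for chloro on this aromatic carbon, ortho to a cyclopropylmethoxy group, gives a 3.0-fold higher number from compound 2 to compound 3 (0.47 log units; beyond the scatter) and so provides the first direct measure of this change. With chloro held in place, cyclopropyl in place of difluoromethyl on the chain gives a 2.5-fold higher number from compound 1 to compound 3 (0.40 log units; beyond the scatter) as well, so each of these two places can move the read-out, which compound 1 and compound 2 could not show because they differ in both places at once. Nothing available here explains why the number rises in either step.

Whether chloro gives a step of this size with other chains on the oxygen stays open, as only one such pair is shown. Also open, from the compounds shown here alone, is what bromo or a methyl group on this aromatic carbon would do.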